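Phenyl in Place of Pyridinylmethyl on the Amide Nitrogen

The source may hold more compounds than are shown below. What is called first, only, known or untested is meant among the compounds shown, and "the series" means these compounds.

Compound 1 `N[C@H]1CC[C@H](Nc2c(C(=O)NCc3ccccn3)nc(Br)c3cccnc23)CC1` has been tested in a functional assay on MDA-MB-435 cells (Homo sapiens) for cytotoxicity, read by MTT assay, with a stated time of 72 h (a lower number here means a stronger inhibitor, a higher number a weaker inhibitor), where compound 1 gives 4000 nM. This is the lower of the two numbers recorded so far; in this assay compound 2 `NCCNc1c(C(=O)NCc2ccc(F)cc2)nc(Br)c2cccnc12` gives 12000 nM, a higher value lying beyond the scatter. Compound 3 `N[C@H]1CC[C@H](Nc2c(C(=O)Nc3ccccc3)nc(Br)c3cccnc23)CC1` differs from compound 1 by phenyl in place of (pyridin-2-yl)methyl on an amide-type nitrogen. Going by the values given here, no measured pair shares this change, so its direction is not fixed by the data. For compound 3 the expected step of a 1.4-fold higher number from compound 1 to compound 3 (0.14 log units; within the scatter) is small, toward a higher number, and within the scatter. In this assay compound 3 is estimated at 5500 nM, within a range from 1800 nM to 17000 nM.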

Compound 3, half-maximal inhibitory concentration: 1000 nM
Beside the measured number, compound 3's estimate is 5.5-fold (0.74 log units) above it; the whole stated range lies above it.
By their numbers in this assay, from the lowest: compound 3; then compound 1; then compound 2.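

In this assay, going by these compounds alone, the group on the amide-type nitrogen proves able to shift the number: the change to phenyl gives a 4.0-fold lower number from compound 1 to compound 3 (0.60 log units; beyond the scatter), the first comparison of compounds differing in one place. With the rest of compound 1 unchanged, the (pyridin-2-yl)methyl group is thus not required for this activity. Nothing available explains the step.

The compounds shown leave open whether the step belongs to the ring nitrogen or to the methyl link, which benzyl on the same nitrogen would separate. They also leave open whether a chlorophenyl there would lower the number further.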